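A few compounds are considered here, and "the series" means these few. Any claim that something is new, unique, unknown or untested is made for them only; others in the source may bear on it.

Compound 1 `CC(C)(C)OC(=O)N1CCC(c2coc3c(N4CCCc5cc(S(C)(=O)=O)ccc54)ncnc23)CC1`: 793 nM
Compound 2 `CCc1cnc(N2CCC(c3coc4c(N5CCc6cc(S(C)(=O)=O)ccc65)ncnc34)CC2)nc1`: 41 nM
Compound 3 `Cn1cc(C2CCN(C(=O)OC(C)(C)C)CC2)c2ncnc(Nc3ccc(S(C)(=O)=O)cc3F)c21`: > 1000 nM

In a functional assay on cells for agonist activity at Glucose-dependent insulinotropic receptor (Homo sapiens), read by a luciferase reporter, with a stated time of 4 h (a lower number here means that less compound is needed, a higher number that more compound is needed for the effect), compound 3 gives > 1000 nM; this is a limit of the assay, not a number. Compound 3 thus sits at the limit of > 1000 nM in this assay, at which 1 of the 3 values shown sits, the weak end of what was seen here. In the same assay compound 1 gives 793 nM and compound 2 gives 41 nM, both as numbers.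

Compound 4 `CC(C)(C)OC(=O)N1CCC(c2c[nH]c3c(Nc4ccc(S(C)(=O)=O)cc4F)ncnc23)CC1` differs from compound 3 by hydrogen in place of methyl on an aromatic nitrogen. Within the data shown here, no measured pair of compounds shows this change on its own, so nothing measured says how large its effect is. The step from compound 3 to compound 4 is expected to stay within the scatter, a step that the limit leaves unreadable from compound 3 to compound 4. Compound 4 is therefore estimated at 1500 nM, with a range from 400 nM to 6000 nM.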

Compound 4, half-maximal effective concentration: > 1000 nM
Compound 4 ended at the assay's limit; the forecaster's own chance of this, stated with the estimate: 60%; the middle value lies beyond the limit too.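

Among these compounds, compound 3 and compound 4 both end at a limit of the assay rather than at a number, so no step between them can be read: the limit of > 1000 nM in this assay, at which 2 of the 4 values shown sit.

The compounds shown leave open how large the effect in this assay of hydrogen in place of methyl on an aromatic nitrogen is.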